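From trifluoromethyl to methoxy on a weak growth inhibitor

This account rests on a few compounds, and the source may have more. Where it says the series, first, only, none or still open, it means among the compounds named here.

compound 1 `CC1(/C=C/c2ccccc2C(F)(F)F)C=CC(=O)O1`: 573000 nM
compound 2 `COc1c(O)ccc(/C=C/C2(C)C=CC(=O)O2)c1OC`: > 1000000 nM

Within the data shown here, in a functional assay on K562 cells (Homo sapiens) for inhibition, read by sulforhodamine B assay, with a stated time of 48 h (a higher number here means a weaker inhibitor of growth, a lower number a stronger inhibitor of growth), compound 1 gives 573000 nM, the only actual number so far. Compound 2 also carries methoxy and reads > 1000000 nM, which is a limit of the assay and not a number. Compound 3 `COc1ccccc1/C=C/C1(C)C=CC(=O)O1` differs from compound 1 in one place, with methoxy in place of trifluoromethyl on an aromatic carbon. Among the measured compounds shown here, no measured pair shows this change, so only a small shift toward weaker inhibition is expected in this assay, perhaps none beyond the scatter. The estimated step is a 1.3-fold higher number from compound 1 to compound 3 (0.12 log units; within the scatter). For compound 3 the estimate is 750000 nM, with an expected range of 350000 nM to 1000000 nM.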

Compound 3, concentration for total growth inhibition: 860000 nM
For compound 3 the middle estimate is 1.1-fold (0.06 log units) below the measured one, and the stated range covers the measured number.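

In this assay, among these compounds, the first measured pair for this change gives a 1.5-fold higher number from compound 1 to compound 3 (0.18 log units; within the scatter) when methoxy takes the place of trifluoromethyl on this aromatic carbon, ortho to a group of 9 heavy atoms. At this position, then, the two groups cannot be told apart in this read-out, and both compounds remain weak growth inhibitors. No measurement shown here explains why the two groups read alike.

On these data alone, whether an amine or a carboxylic acid on this carbon would move the number beyond the scatter remains open. So does whether methoxy would behave the same way on another carbon of the aromatic ring.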